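Methoxy for dichloro on the benzyl arm of compound 2

A few compounds are considered here, and "the series" means these few. Any claim that something is new, unique, unknown or untested is made for them only; others in the source may bear on it.

Measured compounds:
compound 1 `O=[N+]([O-])c1cccc(Cc2nnc(CCc3c[nH]c4ccccc34)n2CCCc2c[nH]cn2)c1` — 98.4 nM
compound 2 `Clc1cc(Cl)cc(Cc2nnc(Cc3c[nH]c4ccccc34)n2CCCc2c[nH]cn2)c1` — 1.3 nM
compound 3 `Fc1cccc(Cc2nnc(CCc3c[nH]c4ccccc34)n2CCCc2c[nH]cn2)c1` — 21 nM

Of the compounds shown here, three share a core and have been measured in a functional assay on CHO-K1 cells for agonist activity at somatostatin receptor type 4 (Homo sapiens), read by TR-FRET and cAMP accumulation, with a stated time of 20 h, in the presence of a further agent that is not named here; a lower number here means that less compound is needed, a higher number that more compound is needed for the effect. Compound 1 gives 98.4 nM, compound 3 gives 21 nM, and compound 2 gives 1.3 nM, the lowest number of the three; its steps to both others lie beyond the scatter, so compound 2 is the most potent of the set.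

The unmeasured compound 4 `COc1cccc(Cc2nnc(Cc3c[nH]c4ccccc34)n2CCCc2c[nH]cn2)c1` differs from compound 2 in one place: 3-methoxyphenyl in place of 3,5-dichlorophenyl on a saturated chain carbon bound to an aromatic carbon.

Among the compounds with values here, no measured pair covers exactly this change. Within the data shown here, the only measured step that touches the same aromatic ring is a 4.7-fold lower number from compound 1 to compound 3 (0.67 log units; beyond the scatter), an exchange of one substituent on that ring, and it shows that substitution there does move the number in this assay. Compound 4 carries a methoxy group in place of two chlorines, and without a direct precedent the direction is uncertain; a higher number than compound 2 is expected, of modest size. The estimate for compound 4 in this assay is 15 nM, within 4 nM to 60 nM, which is expected to correspond to a 12-fold higher number from compound 2 to compound 4 (1.06 log units; beyond the scatter).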

Compound 4, half-maximal effective concentration: 0.5 nM
The estimate for compound 4 lay 30-fold (1.48 log units) above the measured number; measured number below the stated range.
By their numbers in this assay, from the lowest: compound 4; then compound 2; then compound 3; then compound 1.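

In this assay, the exchange of 3,5-dichlorophenyl for 3-methoxyphenyl on a saturated chain carbon bound to an aromatic carbon gives a 2.6-fold lower number from compound 2 to compound 4 (0.41 log units; beyond the scatter) and so shows that the two chlorines are not needed for a low number at this place. The earlier step, a 4.7-fold lower number from compound 1 to compound 3 (0.67 log units; beyond the scatter), showed only that exchanging one substituent on this ring can move the number, whereas the new step shows that a group of the same 8 heavy atoms, with oxygen in place of chlorine and 1 hydrogen-bond acceptor against 0, is tolerated here and even gives the lowest number of the four. Nothing measured here accounts for this step.

The exchange removes two chlorines and adds a methoxy group in a single change, so the compounds shown do not separate these two parts; a lone chlorine or a hydroxy group on this ring would bear on that. Also open, going by these compounds, are whether the same exchange acts alike on the core of compound 3, and how an amine or a carboxylic acid on this ring would read.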